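The compounds below may be only part of what the source reports. "The series", "measured", "known", "first", "only" and "open" are said of these compounds alone.

Compound 3 `CCCCCc1ccc(-c2cc3cn([C@H]4C[C@H](O)[C@@H](CO)O4)c(=O)nc3s2)cc1` carries a pentyl chain on the aromatic ring that hangs from the shared core. In a functional assay on HeLa cells (Homo sapiens) for cytotoxicity, read by microscopy (on this read-out higher numbers stand for lower toxicity in this test and lower numbers for higher toxicity in this test), compound 3 gives 50000 nM. Compound 2 `CCCCCCCc1ccc(-c2cc3cn([C@H]4C[C@H](O)[C@@H](CO)O4)c(=O)nc3s2)cc1`, with a heptyl chain in the same place, gives 50000 nM in this assay. The step of no change at the digits printed from compound 2 to compound 3 (within the scatter) is flat: removing ethyl from the chain end moved nothing that the digits show. Compound 1 `CCCCCCCCc1ccc(-c2cc3cn([C@H]4C[C@H](O)[C@@H](CO)O4)c(=O)nc3s2)cc1` carries an octyl chain. For compound 1, this assay reports only a limit, >= 20000 nM, not a number, and this is the bound described by the limit of >= 20000 nM in this assay, at which 1 of the 3 values shown sits. That value is a limit, so the steps a step that the limit leaves unreadable from compound 1 to compound 2 and a step that the limit leaves unreadable from compound 1 to compound 3 cannot be read for size. Compound 3 thus stands level with compound 2, with the third value a limit that says nothing against either.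

Among the compounds with values here, compound 4 `CCc1ccc(-c2cc3cn([C@H]4C[C@H](O)[C@@H](CO)O4)c(=O)nc3s2)cc1` shortens the chain again. hydrogen in place of propyl on a saturated chain carbon, two bonds along the chain from an aromatic carbon The one readable step, no change at the digits printed from compound 2 to compound 3 (within the scatter), gave no change when the chain was cut back, and this is the only guide available. The expected step of no change at the digits printed from compound 3 to compound 4 (within the scatter) is therefore none beyond the scatter. Compound 4 is expected to give 50000 nM in this assay, with a range from 20000 nM to 100000 nM.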

Compound 4, minimum cytotoxic concentration: > 200000 nM
Compound 4 was reported as a limit (the forecaster's own chance of this, stated with the estimate: 35%); at least 4.0-fold (0.60 log units) between middle value and limit.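

Shortening the chain changed nothing measurable from heptyl to pentyl, but at this position the read-out does respond once the chain is cut back to ethyl. In this assay, the change shows as an at least 4.0-fold higher number from compound 3 to compound 4 (0.60 log units; beyond the scatter), and the comparison with the heptyl chain shows as an at least 4.0-fold higher number from compound 2 to compound 4 (0.60 log units; beyond the scatter). Higher numbers here stand for lower toxicity in this test, so the ethyl chain of compound 4 gives less toxicity than the pentyl and heptyl chains, and the value for compound 4 is a limit and not a number: the limit of > 200000 nM in this assay, at which 1 of the 4 values shown sits.

On these data alone, compound 1 also has a limit, so the steps that involve it cannot be read for size, and how the octyl chain compares with the shorter chains stays open: the limit of >= 20000 nM in this assay, at which 1 of the 4 values shown sits. The compounds shown also leave open where between ethyl and pentyl the change sets in, which a propyl or butyl chain could narrow down, and whether a methyl group or an amine in the same place would read like the ethyl chain.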